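Methylsulfanyl in place of hydroxy on a benzyl purine core

The source may hold more compounds than are shown below. What is called first, only, known or untested is meant among the compounds shown, and "the series" means these compounds.

Compound 1 `Nc1nc(O)nc2c1nc(O)n2Cc1ccccc1`, 0.1 uM; compound 3 `COc1cccc(Cn2c(O)nc3c(N)ncnc32)c1`, 10 uM; compound 2 `COc1nc2c(N)ncnc2n1Cc1ccccc1`, > 10 uM.

In a functional assay (spleen, spleen) for activation, with Mus musculus as the target (a higher number here means that more compound is needed for the effect, a lower number that less compound is needed), compound 1 holds the lowest of the two numbers measured, with compound 3 sitting at a far higher number, a gap beyond the scatter. Compound 2 reaches only (the limit of > 10 uM in this assay, at which 1 of the 3 values shown sits), which is a limit of the assay and not a number. Compound 4 `CSc1nc(N)c2nc(O)n(Cc3ccccc3)c2n1` differs from compound 1 in one place: methylsulfanyl in place of hydroxy on an aromatic carbon. For the measured compounds named here, no step between measured compounds matches this change. Compound 4 is expected to land close to compound 1, with the step of a 2.0-fold lower number from compound 1 to compound 4 (0.30 log units; within the scatter) estimated to favour a somewhat lower number. Compound 4 is estimated at 0.05 uM, within 0.01 uM to 0.3 uM.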

Compound 4, minimum effective concentration: 0.1 uM
For compound 4 the middle estimate is 2.0-fold (0.30 log units) below the measured one; the measured number falls inside the stated range.
By their numbers in this assay, from the lowest: compounds 1 and 4 (each within the scatter of the next); then compound 3.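

Methylsulfanyl in place of hydroxy on this aromatic carbon, between two ring nitrogen atoms, gives no change at the digits printed from compound 1 to compound 4 (within the scatter) in this assay. This position therefore tolerates the loss of the hydroxy hydrogen-bond donor and the gain of a second heavy atom, at least for this one group, with no shift beyond the scatter. Nothing available offers an explanation for this result.

As far as these compounds go, whether an amine or a longer chain such as butylsulfanyl on this same carbon would also hold the number in this assay remains open. So does whether the tolerance would persist with a different substituent on the benzyl ring.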